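The compounds below may be only part of what the source reports. "The series", "measured", "known", "first", "only" and "open" are said of these compounds alone.

Measured so far in an ADME assay on RD cells (Homo sapiens) for cytotoxicity; on this read-out higher numbers stand for lower toxicity in this test and lower numbers for higher toxicity in this test:

Compound 1 `Cc1ccc(NC(=O)N/N=C2\C(=O)Nc3ccccc32)cc1` gives > 25000 nM, which is a limit of the assay and not a number.
Compound 2 `COc1cccc(NC(=O)N/N=C2\C(=O)Nc3ccccc32)c1` gives > 25000 nM, again a limit of the assay.
Compound 3 `O=C1Nc2ccc(F)cc2/C1=N/NC(=S)Nc1ccccc1` gives > 25000 nM, also a limit of the assay.

Compound 3 therefore stands at the limit of > 25000 nM in this assay, at which 3 of the 3 values shown sit; compound 1 and compound 2 stand at the same point, so nothing in these numbers sets any of the three apart, and no order among them can be read.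

Compound 4 `Cc1ccc2c(c1)/C(=N/NC(=S)Nc1ccccc1)C(=O)N2` has not yet been measured in this assay. It differs from compound 3 in one place: methyl in place of fluoro on an aromatic carbon, in words methyl in place of fluoro on an aromatic carbon of the shared core. Within the data shown here, no pair of measured compounds in this set differs in a single place, so no step of this kind has been observed directly.

Since compound 3 sits at > 25000 nM, which is a limit of the assay, the step to compound 4 is expected to be none beyond the usual scatter. Compound 4 is therefore expected to give about 30000 nM, with a range from 12000 nM to 120000 nM. The expected step that the limit leaves unreadable from compound 3 to compound 4 is small, and in all likelihood the assay will again report only a limit.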

Compound 4, half-maximal cytotoxic concentration: > 25000 nM
Compound 4: a limit, no number (the forecaster's own chance of this, stated with the estimate: 85%); the middle value does not contradict the limit.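

No step can be read from compound 3 to compound 4, because each gives only a limit of the assay and not a number: the limit of > 25000 nM in this assay, at which 4 of the 4 values shown sit. The compounds shown leave open which structure, if any, would give a measurable value in this assay.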